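This account rests on a few compounds, and the source may have more. Where it says the series, first, only, none or still open, it means among the compounds named here.

For the measured compounds named here, in a functional assay on HepG2 cells (Homo sapiens) for antiproliferative activity, read by MTT assay, with a stated time of 48 h (on this read-out higher numbers stand for weaker inhibition and lower numbers for stronger inhibition), compound 1 (`COc1ccc(CN(C(=O)Cn2cc(COc3cc(=O)oc4ccccc34)nn2)c2cc(OC)c(OC)c(OC)c2)cc1`) gives 6250 nM and compound 2 (`COc1ccc(CN(C(=O)Cn2cc(COc3ccc4c(C)cc(=O)oc4c3)nn2)c2cc(OC)c(OC)c(OC)c2)cc1`) gives 1740 nM as the lower of the two numbers so far. Compound 3 (`COc1ccc(CN(C(=O)Cn2cc(COc3ccccc3)nn2)c2cc(OC)c(OC)c(OC)c2)cc1`) keeps the shared core and differs from compound 2 by a single change, which is a group of 6 heavy atoms (6 carbon; one six-membered aromatic ring of carbon only) in place of a group of 12 heavy atoms (10 carbon, 2 oxygen; one six-membered aromatic ring of carbon only, one six-membered aromatic ring with 1 hetero atom), on an oxygen on a saturated carbon and so puts phenyl on that oxygen. Going by the values given here, only one measured step bears on this: a 3.6-fold lower number from compound 1 to compound 2 (0.56 log units; beyond the scatter) when one group gave way to a slightly larger one with the same ring types. Among the compounds with values here, that step shows that a change at this oxygen can move the number, but no measured compound carries phenyl there, so it is only a weak guide. A modest rise in this assay is expected, towards weaker inhibition, with wide uncertainty. The expected change is a 4.0-fold higher number from compound 2 to compound 3 (0.60 log units; beyond the scatter) in this estimate. Compound 3 is estimated at 7000 nM with 2000 nM to 30000 nM as the expected range.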

Compound 3, half-maximal inhibitory concentration: 20500 nM
Estimate against measurement, compound 3: 2.9-fold (0.47 log units) below, within the range that was stated.
By their numbers in this assay, from the lowest: compound 2; then compound 1; then compound 3.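

In this assay phenyl on the oxygen gives a higher number, meaning weaker inhibition, than either of the two larger groups it replaces, with a large step from one (a 12-fold higher number from compound 2 to compound 3 (1.07 log units; beyond the scatter)) and a modest step from the other (a 3.3-fold higher number from compound 1 to compound 3 (0.52 log units; beyond the scatter)). Among these three compounds, then, the single carbon ring gives the weakest inhibition, and the group in compound 2, which adds a second ring with one hetero atom, gives the strongest. The choice of group at this position can therefore shift the result substantially in either direction, and no measurement shown here explains why.

As far as these compounds go, it remains open how a much smaller or non-aromatic group on this oxygen, such as methyl, an amine or a carboxylic acid, would compare. The three compounds also cannot show which part of the larger groups accounts for the lower numbers.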